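Swapping Fluoro for Hydrogen on Compound 2

A few compounds are considered here, and "the series" means these few. Any claim that something is new, unique, unknown or untested is made for them only; others in the source may bear on it.

Going by the values given here, compound 1 `Cc1c(Cc2ccccc2)c(=O)oc2cc(OCCOc3no[n+]([O-])c3S(=O)(=O)c3ccccc3)ccc12` and compound 2 `COc1cc(OCCOc2no[n+]([O-])c2S(=O)(=O)c2ccccc2)ccc1C(=O)/C=C/c1ccc(F)cc1` are the only two compounds with numbers so far. In a functional assay on MCF7 cells (Homo sapiens) for antiproliferative activity, read by MTT assay, with a stated time of 48 h (a higher number here means a weaker inhibitor, a lower number a stronger inhibitor), compound 1 gives 2350 nM and compound 2 gives 1410 nM as its half-maximal inhibitory concentration. These two numbers lie within the usual scatter of each other, so compound 2 stands level with compound 1.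

Compound 3 `COc1cc(OCCOc2no[n+]([O-])c2S(=O)(=O)c2ccccc2)ccc1C(=O)/C=C/c1ccccc1` differs from compound 2 in one place: hydrogen in place of fluoro on an aromatic carbon, para to a large group, which turns 4-fluorophenyl into phenyl hydrogen in place of fluoro on an aromatic carbon and changes nothing else. Among the compounds with values here, no measured pair shows this kind of change, so the data give no direction, and no step beyond the scatter is expected in this assay here. The estimated 1.1-fold higher number from compound 2 to compound 3 (0.05 log units; within the scatter) stays within that scatter. For compound 3 the expected value is 1600 nM with a range from 650 nM to 4000 nM in this estimate.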

Compound 3, half-maximal inhibitory concentration: 1870 nM
Compound 3: the middle estimate sits 1.2-fold (0.07 log units) below what was measured; low and high end bracket the measured number.
By their numbers in this assay, from the lowest: compounds 2, 3 and 1 (each within the scatter of the next).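

Going by these compounds alone, compound 2 and compound 3 are the first pair here that differ in only one place, so the fluoro on the 4-fluorophenyl group can be judged on its own. In this assay, replacing it with hydrogen gives a 1.3-fold higher number from compound 2 to compound 3 (0.12 log units; within the scatter), so the two compounds stand level and this position tolerates either atom in this assay. Nothing measured here explains this result.

As far as these compounds go, it remains open whether a chloro, an amine or a carboxylic acid at the same place would move the number beyond the scatter. This single pair also cannot tell whether the same swap would have so little effect on the core of compound 1 or in any other assay.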